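The source may hold more compounds than are shown below. What is called first, only, known or untested is meant among the compounds shown, and "the series" means these compounds.

Compound 1 `N#Cc1cc(NC(=O)CN2C(=O)/C(=C/c3ccc(-c4ccc(Cl)cc4)o3)SC2=S)ccc1C(F)(F)F` and compound 2 `Cc1ccc(CNC(=O)CN2C(=O)/C(=C/c3ccc(-c4ccc(Cl)cc4)o3)SC2=S)cc1` share one core and differ only in the group on the amide-type nitrogen. In a functional assay on REH cells (Homo sapiens) for cytotoxicity, read by MTT assay, with a stated time of 72 h (a higher number here means a weaker inhibitor, a lower number a stronger inhibitor), compound 1 gives > 250000 nM, which is a limit of the assay rather than a number. In this assay compound 2 gives 45000 nM. For the measured compounds named here, the step of an at least 5.5-fold lower number from compound 1 to compound 2 (0.74 log units; beyond the scatter) is the only measured comparison in this set. Going by the values given here, compound 2 therefore stands as the only numbered value; the other value shown is a limit. Compound 3 `CCCCCCNC(=O)CN1C(=O)/C(=C/c2ccc(-c3ccc(Cl)cc3)o2)SC1=S` differs from compound 2 by pentyl in place of 4-methylphenyl on a saturated chain carbon bound to an amide-type nitrogen. Among the compounds with values here, no measured step swaps an aromatic group for a chain at this place; the single known step, an at least 5.5-fold lower number from compound 1 to compound 2 (0.74 log units; beyond the scatter), concerns a different pair of groups and is at least modest. A step of a 1.3-fold higher number from compound 2 to compound 3 (0.12 log units; within the scatter) in this assay is expected, not clearly beyond the scatter. Compound 3 is expected to give 60000 nM, with a range from 20000 nM to 200000 nM.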

Compound 3, half-maximal inhibitory concentration: 55000 nM
Compound 3: middle estimate off by 1.1-fold (0.04 log units), on the high side; the measured number falls inside the stated range.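

In this assay, for the compounds shown here, the first swap of an aromatic group for an open chain at this place leaves compound 2 and compound 3 indistinguishable: a 1.2-fold higher number from compound 2 to compound 3 (0.09 log units; within the scatter). The hexyl group of compound 3, like the 4-methylbenzyl group of compound 2, also gives a lower number than the 3-cyano-4-(trifluoromethyl)phenyl group, with an at least 4.5-fold lower number from compound 1 to compound 3 (0.65 log units; beyond the scatter), so two quite different groups on the amide-type nitrogen now stand on the same side of compound 1. Compound 1 holds a limit of the assay, not a number: the limit of > 250000 nM in this assay, at which 1 of the 3 values shown sits.

On these data alone, whether an amine or a carboxylic acid at the end of the chain, or a longer chain such as decyl, would move the number beyond the scatter stays open. The compounds shown also do not separate the saturated carbon on the amide-type nitrogen from the nitrile and trifluoromethyl groups of compound 1.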